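Cytotoxicity notes on a shared-core series

A few compounds are considered here, and "the series" means these few. Any claim that something is new, unique, unknown or untested is made for them only; others in the source may bear on it.

Measured so far in an ADME assay on CCRF-HSB-2 cells (Homo sapiens) for cytotoxicity, with a stated time of 7 days; on this read-out lower numbers stand for higher toxicity in this test and higher numbers for lower toxicity in this test:
compound 1 `C=CCOc1nc(N)nc2c1ncn2/C=C1/CC1(CO)CO` gives > 20000 nM
compound 2 `CCCSc1nc(N)nc2c1ncn2/C=C1/CC1(CO)CO` gives 98000 nM
compound 3 `CC(C)Nc1nc(N)nc2c1ncn2/C=C1/CC1(CO)CO` gives > 20000 nM

Compound 3 has only a limit in this assay, not a number; it sits at the limit of > 20000 nM in this assay, at which 2 of the 3 values shown sit. Compound 1 likewise sits at that limit. Among the measured compounds shown here, the single numerical value in the set belongs to compound 2. The steps connecting the three are therefore not readable: a step that the two limits leave unreadable from compound 1 to compound 3, a step that the limit leaves unreadable from compound 2 to compound 3 and a step that the limit leaves unreadable from compound 1 to compound 2 cannot be sized, and no direction can be drawn from them.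

The next compound, compound 4 `CCCCOc1nc(N)nc2c1ncn2/C=C1/CC1(CO)CO`, differs from compound 3 by butoxy in place of isopropylamino on an aromatic carbon. For the measured compounds named here, none of the measured steps bears on this change in a readable way; they only show that every compound measured so far is weakly cytotoxic or below the limit of this assay. Compound 4 is therefore expected to sit in the same low-toxicity region, with the step that the limit leaves unreadable from compound 3 to compound 4 expected to be none beyond the scatter. The estimate for compound 4 in this assay is 50000 nM, with a range from 15000 nM to 200000 nM.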

Compound 4, half-maximal cytotoxic concentration: > 20000 nM
Compound 4 gave a limit, no number; the forecaster's own chance of this, stated with the estimate: 60%; the middle value lies beyond the limit too.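

Compound 4 gives a limit rather than a number in this assay, so no new step can be read between it and compound 1, compound 2 or compound 3: the limit of > 20000 nM in this assay, at which 3 of the 4 values shown sit.

The compounds shown leave open whether butoxy, allyloxy and isopropylamino on the shared core differ from one another or from propylsulfanyl in this assay.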